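The source may report more compounds than this note shows. Statements on the series, on what has been measured and on what is new or still open speak of the compounds shown alone.

Compound 1 `CCCOc1cc(C(=O)N(C)C)nn1-c1ccccc1`: 26.2%
Compound 2 `CCCCOc1cc(C(=O)N(C)C)nn1-c1ccccc1`: 18.7%

Both have been tested in a functional assay on the whole organism (strain Wistar) for inhibition, with Rattus norvegicus as the target, read by paw edema, with stated times of 30 min and 3 h, at a dose of 100 mg/kg by the oral route; a higher number here means more inhibition at the dose given (going by the name of the read-out), a lower number less inhibition. Going by the values given here, compound 1 gives 26.2% and compound 2 gives 18.7%; the one step measured between them, a number 7.5 percentage points lower from compound 1 to compound 2 (within the scatter), places the two within the usual scatter of each other, so compound 2 stands level with compound 1 rather than apart from it. Compound 3 `CCCCOc1cc(C(=O)N(CC)CC)nn1-c1ccccc1` has not been measured. It differs from compound 2 by diethylamino in place of dimethylamino on a carbonyl carbon. Among the compounds with values here, no measured step bears on this change: the only step known, a number 7.5 percentage points lower from compound 1 to compound 2 (within the scatter), concerns the chain attached to the oxygen, not the carbonyl carbon, and itself lies within the scatter. With nothing pointing either way, no step beyond the scatter is expected in this assay, and the expected step is a number 0.3 percentage points higher from compound 2 to compound 3 (within the scatter). Compound 3 is therefore estimated at 19%, with a range from 7% to 32%.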

Compound 3, a percentage reported as inhibition, in the whole organism at one dose (the size of the read-out at that dose, not a potency): 44.1%
The estimate for compound 3 lay 25.1 percentage points below the measured number, outside the stated range (above it).
By their numbers in this assay, from the lowest: compounds 2 and 1 (each within the scatter of the next); then compound 3.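

In this assay, going by these compounds alone, the group on the carbonyl carbon proves able to move the result: diethylamino in place of dimethylamino gives a number 25.4 percentage points higher from compound 2 to compound 3 (beyond the scatter) and this lies beyond the usual scatter, whereas the one earlier step, on the chain attached to the oxygen, stayed within it. The change itself is simple, since neither group carries a ring or a net charge and only methyl arms give way to ethyl arms. No measurement here bears on the reason for this rise.

Going by these compounds, whether the rise would continue with dipropylamino in the same place, or survive with a ring amine such as piperidinyl, remains open. Also open, on these data alone, is whether diethylamino would give a similar step on the propyl chain of compound 1.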